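The compounds below may be only part of what the source reports. "The series", "measured", "known", "first", "only" and "open" are said of these compounds alone.

Compound 1 `COc1ccc(SCc2ccc(C(=O)Nc3ccccc3N)cc2)cc1`: 3010 nM
Compound 2 `Nc1ccccc1NC(=O)c1ccc(CSc2nccc(C(F)(F)F)n2)cc1`: 1550 nM

Both values come from a functional assay on A-375 cells (Homo sapiens) for antiproliferative activity, read by CCK-8 assay, with a stated time of 72 h; a higher number here means a weaker inhibitor, a lower number a stronger inhibitor. Compound 1 and compound 2 stand within the usual scatter of each other, so the two numbers give no order. Compound 3 `Cc1cc(C)cc(SCc2ccc(C(=O)Nc3ccccc3N)cc2)c1` has 3,5-dimethylphenyl in place of 4-methoxyphenyl on a sulfur, with the rest of compound 1 kept: 3,5-dimethylphenyl in place of 4-methoxyphenyl on a sulfur. Among the compounds with values here, no single-change step has been measured, so the expectation in this assay is for no change beyond the scatter, in either direction. The expected change is a 1.2-fold lower number from compound 1 to compound 3 (0.08 log units; within the scatter). For compound 3 the estimated value is 2500 nM, with an expected range of 800 nM to 7000 nM.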

Compound 3, half-maximal inhibitory concentration: 3670 nM
For compound 3 the middle estimate is 1.5-fold (0.17 log units) below the measured one, and the stated range covers the measured number.
By their numbers in this assay, from the lowest: compounds 2, 1 and 3 (each within the scatter of the next, the first and the last beyond it).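

In this assay, within the data shown here, the change from 4-methoxyphenyl to 3,5-dimethylphenyl on a sulfur gives a 1.2-fold higher number from compound 1 to compound 3 (0.09 log units; within the scatter) as the only single-change step read so far. The entering group has the same heavy-atom count but no hydrogen-bond acceptor, and the two compounds are not separated at this position. No accompanying measurement bears on why this is so. Still open, as far as these compounds go, is whether a phenyl carrying an amine or a carboxylic acid would separate from compound 1 in this assay. Also open, from the compounds shown here alone, is whether a longer chain on the sulfur would do so.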